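This account rests on a few compounds, and the source may have more. Where it says the series, first, only, none or still open, it means among the compounds named here.

Compound 2, `COc1ccc(OC)c(/C=C/C(=O)N/N=C/c2ccc(Cl)cc2)c1`, gives 350 nM in a functional assay on OVCAR-8 cells (Homo sapiens) for antiproliferative activity, read by sulforhodamine B assay, with a stated time of 48 h; a higher number here means a weaker inhibitor of growth, a lower number a stronger inhibitor of growth.
Compound 1, `COc1ccc(OC)c(/C=C/c2nnc(Nc3ccc(Cl)cc3)o2)c1`, gives 4910 nM in this assay.

Of these two numbers compound 2 stands lowest; compound 1 sits higher by a gap beyond the usual scatter. Compound 3, `COc1ccc(OC)c(/C=C/C(=O)N/N=C/c2ccccc2)c1`, differs from compound 2 by hydrogen in place of chloro on an aromatic carbon. Going by the values given here, no measured pair shows this change, so its size is open; a small rise in the number, perhaps no more than the scatter, is expected. The estimate for compound 3 is 600 nM, with a range from 200 nM to 2000 nM. The expected step is a 1.7-fold higher number from compound 2 to compound 3 (0.23 log units; within the scatter).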

Compound 3, concentration for 50% growth inhibition: 5440 nM
Estimate against measurement, compound 3: 9.1-fold (0.96 log units) below; measured number outside the range, above it.
By their numbers in this assay, from the lowest: compound 2; then compounds 1 and 3 (each within the scatter of the next).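

In this assay, going by these compounds alone, the change from 4-chlorophenyl to phenyl gives a 16-fold higher number from compound 2 to compound 3 (1.19 log units; beyond the scatter) and is the first direct reading of this position. It shows that the aromatic carbon para to a large group is not indifferent to its substituent: here, chloro carries a step beyond the scatter. Nothing available explains the size of this step.

From the compounds shown here alone, what a bromine, a methoxy group or an amine on that same carbon would give remains open. This step has been measured for chloro only. Going by these compounds, whether other groups there would give a similar step is also open.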